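The source may report more compounds than this note shows. Statements on the series, on what has been measured and on what is new or still open speak of the compounds shown alone.

Compound 3 `Cc1nn(C)c(Oc2ccc(F)cc2)c1/C=N\OCc1c(Cl)c(-c2ccc(Cl)cc2)nn1C` and compound 1 `CCc1nn(C)c(CO/N=C/c2c(C)nn(C)c2Oc2ccccc2F)c1Cl` carry different cores; the difference between the two cores is not broken down here. In a functional assay on SMMC-7721 cells (Homo sapiens) for inhibition, read by MTT assay, with a stated time of 72 h, tested at 25 uM (on this read-out higher numbers stand for more inhibition at the one concentration tested (going by the name of the read-out) and lower numbers for less inhibition), compound 3 gives 80%. Compound 1 reaches only a limit of this assay, < 80%. Compound 2 `CCc1nn(C)c(CO/N=C/c2c(C)nn(C)c2Oc2ccccc2Cl)c1Cl` likewise shows only a limit, < 80%. The change from compound 1 to compound 2, (chloro in place of fluoro on an aromatic carbon), gives a step that the two limits leave unreadable from compound 1 to compound 2. Compound 4 `Cc1nn(C)c(Oc2ccc(Cl)cc2)c1/C=N\OCc1c(Cl)c(-c2ccc(Cl)cc2)nn1C` arises from compound 3 by the same kind of change, (chloro in place of fluoro on an aromatic carbon), though here the place is para to a large group rather than ortho to it. Since compound 3 gives 80% and the unreadable step leaves little to lean on, compound 4 is expected to show a step of about no change at the digits printed from compound 3 to compound 4 (within the scatter). The risk noted in the limit of < 80% in this assay, at which 2 of the 3 values shown sit, remains, namely that compound 4 again lands at a limit of this assay. The estimate for compound 4 is therefore 80%, between 55% and 95%.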

Compound 4, a percentage reported as inhibition, at one concentration (the size of the read-out at that concentration, not a potency): 80%
Estimate against measurement, compound 4: no gap at the digits printed; the measured number falls inside the stated range.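

In this assay, chloro in place of fluoro on an aromatic carbon gives no change at the digits printed from compound 3 to compound 4 (within the scatter), so on the core of compound 3 this swap leaves the reading unmoved. This one pair does not show that the swap behaves alike on every core in the series. The matching step on the core of compound 1 cannot be read, because compound 1 and compound 2 both sit at a limit, so no comparison between the two cores is possible: the limit of < 80% in this assay, at which 2 of the 4 values shown sit.

The compounds shown leave open what an amine or a methoxy group would do in place of the halogen of the 4-fluorophenoxy group. On these data alone, a percentage at one concentration is also not a potency, so how compound 3 and compound 4 compare across a range of concentrations stays unknown.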